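This account rests on a few compounds, and the source may have more. Where it says the series, first, only, none or still open, it means among the compounds named here.

Measured in an ADME assay on HEK293 cells (Homo sapiens) for inhibition, read by MTT assay, with stated times of 18 h and 4 h; on this read-out higher numbers stand for weaker inhibition and lower numbers for stronger inhibition:
compound 1 `CCCOP(=O)(O)OCCSC(=S)N1CCCCC1`: > 100000 nM, a limit of the assay
compound 2 `CCCCCCCCOP(=O)(O)OCCSC(=S)N1CCCCC1`: 69000 nM
compound 3 `CCCCCCOP(=O)(O)OCCSC(=S)N1CCCCCC1`: 70500 nM

Compound 3, at 70500 nM, lies within the scatter of compound 2, at 69000 nM. Compound 4 `CCCCCCOP(=O)(O)OCCSC(=S)N1CCCCC1` keeps the alkyl chain of compound 3 and makes one change: piperidin-1-yl in place of azepan-1-yl on a thiocarbonyl carbon. In words, this is piperidin-1-yl in place of azepan-1-yl on a thiocarbonyl carbon.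

Among the compounds with values here, no measured step isolates this ring swap. Within the data shown here, the only measured step, an at least 1.4-fold lower number from compound 1 to compound 2 (0.16 log units; that floor lies within the scatter), is pentyl in place of hydrogen on the chain, and its floor stays within the scatter. Compound 4 shares piperidin-1-yl with compound 1 and compound 2, and its chain is longer than that of compound 1 and shorter than that of compound 2. The data therefore give no reason to expect a change beyond the scatter. The expected step in this assay is a 1.2-fold higher number from compound 3 to compound 4 (0.08 log units; within the scatter), leaning towards weaker inhibition. Compound 4 is estimated at 85000 nM, with an expected range of 55000 nM to 130000 nM.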

Compound 4, half-maximal inhibitory concentration: > 100000 nM
Compound 4: a limit, no number (the forecaster's own chance of this, stated with the estimate: 35%); middle value at least 1.1-fold (0.07 log units) from the limit.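

In this assay, compound 4 gives > 100000 nM, which is a limit of the assay and not a number. On the thiocarbonyl carbon, piperidin-1-yl in place of azepan-1-yl gives an at least 1.4-fold higher number from compound 3 to compound 4 (0.15 log units; that floor lies within the scatter), and hydrogen in place of ethyl on the chain gives an at least 1.4-fold higher number from compound 2 to compound 4 (0.16 log units; that floor lies within the scatter), so these floors alone do not show that either change weakens inhibition beyond the scatter. The step between compound 1 and compound 4 cannot be read, because both compounds sit at the limit: the limit of > 100000 nM in this assay, at which 2 of the 4 values shown sit.

On these data alone, how far the true value of compound 4 lies past the limit stays open, and with it the full size of the ring step. Also open, as far as these compounds go, is how morpholin-4-yl on the thiocarbonyl carbon, or a dodecyl chain on the phosphate, would read in this assay.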